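The compounds below may be only part of what the source reports. "The series", "measured", "known", "first", "only" and "open" are said of these compounds alone.

Measured in a functional assay on MDA-MB-231 cells (Homo sapiens) for inhibition, with a stated time of 48 h; a higher number here means that more compound is needed for the effect, a lower number that less compound is needed:
compound 1 `CN[C@@H](C)C(=O)N[C@@H](CSCCS(=O)(=O)CCSC[C@H](NC(=O)[C@H](C)NC)C(=O)N1CCC[C@H]1C(=O)NC(c1ccccc1)c1ccccc1)C(=O)N1CCC[C@H]1C(=O)NC(c1ccccc1)c1ccccc1`: 52400 nM
compound 2 `CN[C@@H](C)C(=O)N[C@@H](CSCc1ccc(CSC[C@H](NC(=O)[C@H](C)NC)C(=O)N2CCC[C@H]2C(=O)NC(c2ccccc2)c2ccccc2)cc1)C(=O)N1CCC[C@H]1C(=O)NC(c1ccccc1)c1ccccc1`: 9600 nM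
compound 3 `CN[C@@H](C)C(=O)N[C@@H](CS)C(=O)N1CCC[C@H]1C(=O)NC(c1ccccc1)c1ccccc1`: > 100000 nM

Compound 3 stands at the weak end of what is shown: its result is a limit of the assay and not a number, and (the limit of > 100000 nM in this assay, at which 1 of the 3 values shown sits). Compound 1 and compound 2 give measured numbers, with compound 2 the lower of the two. Compound 4 `CN[C@@H](C)C(=O)N[C@@H](CCCCN)C(=O)N1CCC[C@H]1C(=O)NC(c1ccccc1)c1ccccc1` differs from compound 3 in one place: 3-aminopropyl in place of sulfanyl on a saturated chain carbon, two bonds along the chain from an amide-type nitrogen and a carbonyl carbon. Going by the values given here, no step between measured compounds is available, so the size of this change rests on expectation alone; with compound 3 already at the limit, the expected step that the limit leaves unreadable from compound 3 to compound 4 is no movement beyond the scatter, most likely another limit. Compound 4 is therefore estimated to give about 120000 nM in this assay, within 40000 nM to 400000 nM.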

Compound 4, half-maximal effective concentration: > 100000 nM
Compound 4 gave a limit, no number; the forecaster's own chance of this, stated with the estimate: 60%; the middle value lies beyond the limit too.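

Compound 4 gives > 100000 nM, a limit of the assay and not a number. Going by these compounds alone, compound 3 is also a limit, so no step between compound 3 and compound 4 can be read. As far as these compounds go, whether 3-aminopropyl in place of sulfanyl changes the effect at all stays open.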